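The source may report more compounds than this note shows. Statements on the series, on what has been measured and on what is new or still open speak of the compounds shown alone.

Of the compounds shown here, three built on one shared core have been measured in an ADME assay for pharmacokinetics, read by LC-MS, in phosphate buffer, with a stated time of 72 h, at pH 7.4, tested at 250 uM; a lower number here means that the compound disappears faster, a higher number that the compound lasts longer. Compound 1 `C#Cc1cc(C(F)(F)F)cc(C(F)(F)F)c1` gives 5.9 h. Compound 2 `N#Cc1cc(C(F)(F)F)cc(C(F)(F)F)c1` gives 50 h. For compound 3 `Fc1cc(C(F)(F)F)cc(C(F)(F)F)c1` the result is only a limit of the assay, > 50 h. Compound 3 therefore stands at the limit of > 50 h in this assay, at which 1 of the 3 values shown sits, and its comparison with compound 2 reads a number no lower from compound 2 to compound 3 (the limit leaves the size open). The next step leads to compound 4 `FC(F)(F)c1cc(S)cc(C(F)(F)F)c1`: sulfanyl in place of fluoro on an aromatic carbon. Going by the values given here, no measured step involves a sulfanyl group; on this same carbon the known steps are an 8.5-fold higher number from compound 1 to compound 2 (0.93 log units; beyond the scatter) and an at least 8.4-fold higher number from compound 1 to compound 3 (0.92 log units; beyond the scatter). Because of an at least 8.4-fold higher number from compound 1 to compound 3 (0.92 log units; beyond the scatter) showing that one group here moves the number strongly, the step expected for compound 4 is an at least 3.3-fold lower number from compound 3 to compound 4 (0.52 log units; beyond the scatter). In this assay compound 4 is estimated at 15 h, within 3 h to 50 h.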

Compound 4, half-life: 33 h
Beside the measured number, compound 4's estimate is 2.2-fold (0.34 log units) below it, and the stated range covers the measured number.
By their numbers in this assay, from the lowest: compound 1; then compounds 4 and 2 (each within the scatter of the next).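

In this assay, a third group on this aromatic carbon, sulfanyl, stands clear of ethynyl: a 5.6-fold higher number from compound 1 to compound 4 (0.75 log units; beyond the scatter). Against cyano, the same change gives a 1.5-fold lower number from compound 2 to compound 4 (0.18 log units; within the scatter), so the two groups cannot be told apart here. Against fluoro, it gives an at least 1.5-fold lower number from compound 3 to compound 4 (0.18 log units; that floor lies within the scatter), and as the result for compound 3 is a limit of the assay, this step fixes no size. The compounds shown leave open whether an amine or a methoxy group on this carbon would sit with compound 1 or with compound 2. They also leave open how far compound 3 truly lies from the others.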